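A few compounds are considered here, and "the series" means these few. Any claim that something is new, unique, unknown or untested is made for them only; others in the source may bear on it.

Compound 1 `Cc1ccc(OCC(=O)NNC(=O)c2cc3ccccc3oc2=O)c(C(=O)c2cccc(Cl)c2)c1` gives 67300 nM in a functional assay on Ehrlich cells (Mus musculus) for cytotoxicity, read by trypan blue exclusion, with a stated time of 48 h; a lower number here means a stronger inhibitor, a higher number a weaker inhibitor. Compound 2 `Cc1ccc(OCC(=O)NNC(=O)c2cc3ccccc3oc2=O)c(C(=O)c2ccccc2Br)c1` gives 9000 nM. Compound 3 `Cc1ccc(OCC(=O)NNC(=O)c2cc3ccccc3oc2=O)c(C(=O)c2ccc(Cl)cc2)c1` gives 57800 nM.

Among these three, compound 1 has the highest number in this assay. Compound 3 sits nearest, and that difference lies within the scatter, a 1.2-fold lower number from compound 1 to compound 3 (0.07 log units; within the scatter). Compound 2 lies furthest away, a 7.5-fold lower number from compound 1 to compound 2 (0.87 log units; beyond the scatter).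

Compound 4 `Cc1ccc(OCC(=O)NNC(=O)c2cc3ccccc3oc2=O)c(C(=O)c2ccc(Br)cc2)c1` is not yet measured. It differs from compound 1 in one place: 4-bromophenyl in place of 3-chlorophenyl on a carbonyl carbon. Two of the measured steps bear on this. The step of a 1.2-fold lower number from compound 1 to compound 3 (0.07 log units; within the scatter) shows that moving the chlorine from 3-chlorophenyl to 4-chlorophenyl changes little. The step of a 6.4-fold higher number from compound 2 to compound 3 (0.81 log units; beyond the scatter) shows that 4-chlorophenyl gives a higher number than 2-bromophenyl. Going by the values given here, no measured pair compares bromine with chlorine in the same position, so the weight of that part of the change is unknown. The expected step is therefore small, a 1.5-fold lower number from compound 1 to compound 4 (0.17 log units; within the scatter), if anything toward a lower number. Compound 4 is estimated at 45000 nM, with a range from 15000 nM to 120000 nM.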

Compound 4, half-maximal inhibitory concentration: 91100 nM
Compound 4: the middle estimate sits 2.0-fold (0.31 log units) below what was measured; the range from low to high includes it.
By their numbers in this assay, from the lowest: compound 2; then compounds 3, 1 and 4 (each within the scatter of the next).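

Going by these compounds alone, the step of a 1.6-fold higher number from compound 3 to compound 4 (0.20 log units; within the scatter) is the first direct comparison of bromo with chloro on an aromatic carbon, and in this assay it stays within the scatter. The 4-bromophenyl group also stays level with the 3-chlorophenyl group, with a 1.4-fold higher number from compound 1 to compound 4 (0.13 log units; within the scatter), so compounds 1, 3 and 4 form one group and compound 2 alone stands apart from it. With bromine present on both sides, the step of a 10-fold higher number from compound 2 to compound 4 (1.01 log units; beyond the scatter) is the largest shown, which ties the lower number to the 2-bromophenyl group and not to bromine as such.

Going by these compounds, whether a 2-chlorophenyl or a 2-methoxyphenyl group on this carbonyl carbon would also give a number as low as that of compound 2 remains open. Nothing shown explains why the 2-bromophenyl group differs from the others.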